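The source may report more compounds than this note shows. Statements on the series, on what has been measured and on what is new or still open speak of the compounds shown alone.

In a functional assay on MGC-803 cells (Homo sapiens) for inhibition, read by CCK-8 assay, with a stated time of 48 h (on this read-out lower numbers stand for stronger inhibition and higher numbers for weaker inhibition), three compounds have been measured so far. Compound 1 `COc1ccc(CN(C(=O)CSC(=S)N2CCN(C(C)=O)CC2)c2cc(OC)c(OC)c(OC)c2)cc1` gives 480 nM. Compound 2 `COc1ccc(CN(C(=O)CSC(=S)N2CCCC2)c2cc(OC)c(OC)c(OC)c2)cc1` reports only a limit, > 20000 nM. Compound 3 `COc1cc(N(Cc2ccc(Br)cc2)C(=O)CSC(=S)N2CCN(C(=O)OC(C)(C)C)CC2)cc(OC)c1OC` gives 12400 nM, the higher of the two actual numbers and well beyond the scatter from compound 1.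

Compound 4 `COc1ccc(CN(C(=O)CSC(=S)N2CCN(C(=O)OC(C)(C)C)CC2)c2cc(OC)c(OC)c(OC)c2)cc1F`, not yet measured, differs from compound 3 in one place: 3-fluoro-4-methoxyphenyl in place of 4-bromophenyl on a saturated chain carbon bound to an amide-type nitrogen. In short, 4-bromobenzyl gives way to 3-fluoro-4-methoxybenzyl.

Going by the values given here, no measured step alters this group. The only one, an at least 41-fold higher number from compound 1 to compound 2 (1.61 log units; beyond the scatter), is large, but it puts pyrrolidin-1-yl in place of 4-acetylpiperazin-1-yl on a thiocarbonyl carbon, so it bears only indirectly by showing how far values can move. Compound 1, at 480 nM, also has a methoxy group on its benzyl, yet it differs from compound 3 in more than one place, which gives only weak support.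

A moderate move to a lower number is therefore expected, a 2.5-fold lower number from compound 3 to compound 4 (0.39 log units; beyond the scatter). For compound 4 the estimated value is 5000 nM, with an expected range from 1000 nM to 20000 nM.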

Compound 4, half-maximal inhibitory concentration: 4870 nM
Compound 4: the middle estimate sits 1.0-fold (0.01 log units) above what was measured; the range from low to high includes it.
By their numbers in this assay, from the lowest: compound 1; then compound 4; then compound 3. At a limit, above all of these: compound 2.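

The change from 4-bromophenyl to 3-fluoro-4-methoxyphenyl in this assay gives a 2.5-fold lower number from compound 3 to compound 4 (0.41 log units; beyond the scatter). Going by these compounds alone, this is the first measured change at this place, on a saturated chain carbon bound to an amide-type nitrogen, and it shows that the group there can move the number while the rest of the structure stays fixed. Compound 2 is the only compound at a limit of the assay rather than a number, so this step, unlike the one into compound 2, has a definite size: the limit of > 20000 nM in this assay, at which 1 of the 4 values shown sits.

From the compounds shown here alone, the fluorine and the methoxy group enter together, so the step cannot be divided between them, and an unsubstituted benzyl or a 4-chlorobenzyl on the shared core remains open. Also open, going by these compounds, is whether the change would have the same size with 4-acetylpiperazin-1-yl on the thiocarbonyl carbon.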